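The source may report more compounds than this note shows. Statements on the series, on what has been measured and on what is new or still open speak of the compounds shown alone.

Measured in a functional assay on cells for agonist activity at Glucose-dependent insulinotropic receptor (Homo sapiens), read by HTRF and cAMP accumulation, with a stated time of 30 min; a lower number here means that less compound is needed, a higher number that more compound is needed for the effect:

compound 1 `CC(C)(C)OC(=O)N1CCC2(CC1)CC(CCCCOc1ccc(S(C)(=O)=O)cc1)C2`: 154 nM
compound 2 `CS(=O)(=O)c1ccc(OCCCC2CC3(CCN(C(=O)OC4CCCC4)CC3)C2)cc1F`: 23 nM
compound 3 `CC(C)OC(=O)N1CCC2(CC1)CC(CCCOc1ccc(C(N)=O)c(F)c1)C2`: 52 nM

Among these three numbers, compound 3 stands second highest. Compound 2 gives the lower number, and that gap lies beyond the usual scatter; compound 1 gives the higher number, also beyond the scatter. Compound 4 `CC(C)OC(=O)N1CCC2(CC1)CC(CCCOc1ccc(C(=O)N(C)C3CC3)c(F)c1)C2` differs from compound 3 in a single place: cyclopropyl(methyl)amino in place of amino on a carbonyl carbon. For the measured compounds named here, no measured pair shows this kind of change, so there is no step to lean on. With nothing in the data pointing either way, the step from compound 3 to compound 4 is expected to be small, a 1.2-fold higher number from compound 3 to compound 4 (0.06 log units; within the scatter), with no clear direction beyond the scatter. Compound 4 is therefore estimated at 60 nM, in a range from 20 nM to 200 nM.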

Compound 4, half-maximal effective concentration: 67 nM
Estimate against measurement, compound 4: 1.1-fold (0.05 log units) below; the range from low to high includes it.
By their numbers in this assay, from the lowest: compound 2; then compounds 3 and 4 (each within the scatter of the next); then compound 1.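

In this assay, putting cyclopropyl(methyl)amino in place of amino on a carbonyl carbon gives a 1.3-fold higher number from compound 3 to compound 4 (0.11 log units; within the scatter). So this position can take a much larger group, one with no hydrogen-bond donor, with no change in the number that stands beyond the scatter. No supporting measurement bears on why the number holds.

Going by these compounds, whether methylamino or cyclopropylamino alone would behave the same remains open, as does the outcome with a ring amine such as pyrrolidine or with a carboxylic acid at this place.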